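The source may hold more compounds than are shown below. What is called first, only, known or untested is meant among the compounds shown, and "the series" means these compounds.

Working notes on the shared core. Compound 1 `Cc1cc(CN/C(S)=N/Cc2ccc(NS(C)(=O)=O)cc2)c(COC(=O)C(C)(C)C)cc1C` gives 70000 nM in a functional assay for inhibition of Vanilloid receptor (Rattus norvegicus); a lower number here means a stronger inhibitor, a higher number a weaker inhibitor. Compound 2 `COc1cc(C(C)(C)C)ccc1C/N=C(\S)NCc1ccc(NS(C)(=O)=O)cc1` gives 2400 nM in this assay. Compound 3 `CCCCCOc1cc(C(C)(C)C)ccc1C/N=C(\S)NCc1ccc(NS(C)(=O)=O)cc1` gives 70 nM in this assay, the lowest of the three numbers; the nearest of the others is compound 2 and the furthest is compound 1, both gaps beyond the scatter. Among single-site steps only one is defined: a 34-fold lower number from compound 2 to compound 3 (1.54 log units; beyond the scatter), a large step, beyond the scatter. Going by the values given here, no single-site step connects compound 1 to either of the others, so those pairs show only their two values.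

Compound 4 `CC(C)(C)c1ccc(C/N=C(\S)NCc2ccc(NS(C)(=O)=O)cc2)c(OCc2ccccc2)c1` differs from compound 3 in one place: phenyl in place of butyl on a saturated chain carbon bound to an oxygen on an aromatic ring. Among the compounds with values here, the one measured step that bears on this is the chain extension from compound 2 to compound 3, which made a large difference in this assay when hydrogen became butyl. Within the data shown here, no measured pair shows what happens when the butyl is exchanged for a ring of similar count rather than extended; the step into compound 4 is expected to be small, in either direction, at most just beyond the scatter, a 1.4-fold higher number from compound 3 to compound 4 (0.15 log units; within the scatter). Compound 4 is therefore estimated at 100 nM in this assay, with a range from 25 nM to 400 nM.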

Compound 4, half-maximal inhibitory concentration: 770 nM
The estimate for compound 4 lay 7.7-fold (0.89 log units) below the measured number, and the stated range ends below it.
By their numbers in this assay, from the lowest: compound 3; then compound 4; then compound 2; then compound 1.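

In this assay the exchange of pentyloxy for benzyloxy is far from neutral at this place, on a saturated chain carbon bound to an oxygen on an aromatic ring: it gives an 11-fold higher number from compound 3 to compound 4 (1.04 log units; beyond the scatter) even though the phenyl that enters has more heavy atoms than the butyl that leaves. Compound 4 still keeps part of the gain over the hydrogen, with a 3.1-fold lower number from compound 2 to compound 4 (0.49 log units; beyond the scatter) set against a 34-fold lower number from compound 2 to compound 3 (1.54 log units; beyond the scatter) for the butyl, so among these three compounds the number depends on which group is attached here and not merely on whether hydrogen has been replaced. Nothing available here accounts for the gap between the phenyl and the butyl.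

From the compounds shown here alone, it remains open whether the ring's aromatic character or the shorter reach of benzyloxy sets this gap apart, which a cyclohexyl group or a phenethyl group at this place could help to separate. Also open, going by these compounds, is whether a chain longer than butyl would go lower than compound 3 or turn back upward, and whether a fluorine or a methoxy group on the phenyl would recover any of the lost ground.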